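This account rests on a few compounds, and the source may have more. Where it says the series, first, only, none or still open, it means among the compounds named here.

Measured so far in an assay on isolated protein for inhibition of Rho-associated protein kinase 2 (Homo sapiens), read by HTRF; on this read-out higher numbers stand for weaker inhibition and lower numbers for stronger inhibition:
compound 1 `O=C(c1ccc2c(c1)CC(c1nc3ccc(-c4cn[nH]c4)cc3c(=O)[nH]1)CO2)C1CC1` — 18 nM
compound 2 `COc1ccc2c(c1)CC(c1nc3c(N(C)CCN(C)C)cc(-c4cn[nH]c4)cc3c(=O)[nH]1)CO2` — 21 nM
compound 3 `COc1cccc2c1OCC(c1nc3ccc(-c4cn[nH]c4)cc3c(=O)[nH]1)C2` — 423 nM

Compound 1 has the lowest number of the three. Compound 2 lies within the usual scatter of it, so no order between these two can be read. Compound 3 lies beyond the scatter, clearly above compound 1.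

The next compound, compound 4 `O=c1[nH]c(C2COc3ccc(F)cc3C2)nc2ccc(-c3cn[nH]c3)cc12`, is not yet measured in this assay. It differs from compound 1 in one place: fluoro in place of cyclopropylcarbonyl on an aromatic carbon. Within the data shown here, no measured pair shows this exchange directly, so its effect has to be guessed from the structures alone. Compound 2, which carries methoxy rather than cyclopropylcarbonyl on its core and gives 21 nM, shows that a small substituent on the core is compatible with a low number. The cyclopropylcarbonyl nevertheless leaves entirely, with its carbonyl. The expected outcome for compound 4 is a modest weakening, a step of a 2.8-fold higher number from compound 1 to compound 4 (0.44 log units; beyond the scatter), near the edge of the scatter. Compound 4 is accordingly estimated at 50 nM, with a range from 15 nM to 170 nM.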

Compound 4, half-maximal inhibitory concentration: 3 nM
Estimate against measurement, compound 4: 17-fold (1.22 log units) above, and the stated range ends above it.
By their numbers in this assay, from the lowest: compound 4; then compounds 1 and 2 (each within the scatter of the next); then compound 3.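

In this assay the exchange of cyclopropylcarbonyl for fluoro on this aromatic carbon gives a 6.0-fold lower number from compound 1 to compound 4 (0.78 log units; beyond the scatter). Among these compounds, a low number at this position therefore does not depend on the cyclopropylcarbonyl, its carbonyl or its three-membered ring, and the single fluorine of compound 4 goes further in the favourable direction than compound 1 does. Nothing available explains the size or direction of this step.

Among the compounds shown here, with only one exchange at this carbon, it remains open whether the lower number belongs to fluoro itself or simply follows the departure of cyclopropylcarbonyl. Plain hydrogen, chloro, nitrile or a primary amine on the same carbon would separate these two readings, and a longer acyl chain would show how much of the larger group can return.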